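Adding a Nitrophenylsulfonyl Group to a Weak Antiproliferative

The source may hold more compounds than are shown below. What is called first, only, known or untested is meant among the compounds shown, and "the series" means these compounds.

For the measured compounds named here, compound 2 `c1ccc(Sc2ncnc3ncn(C4CNc5ccccc5CO4)c23)cc1` is the only compound here with a numerical result: in a functional assay on MCF7 cells (Homo sapiens) for antiproliferative activity (a lower number here means a stronger inhibitor, a higher number a weaker inhibitor), compound 2 gives 48900 nM. Compound 1 `O=[N+]([O-])c1ccc(S(=O)(=O)N2CC(n3cnc4ncnc(O)c43)OCc3ccccc32)cc1` reached only the limit (the limit of > 100000 nM in this assay, at which 1 of the 2 values shown sits), and in this assay compound 1 gives > 100000 nM, which is a limit of the assay rather than a number. Compound 3 `O=[N+]([O-])c1ccc(S(=O)(=O)N2CC(n3cnc4ncnc(Sc5ccccc5)c43)OCc3ccccc32)cc1` differs from compound 2 by (4-nitrophenyl)sulfonyl in place of hydrogen on a nitrogen on an aromatic ring in a ring. The two results above do not show how this change acts, so the expected step is a 1.0-fold higher number from compound 2 to compound 3 (0.01 log units; within the scatter), no larger than the usual scatter. Compound 3 is therefore estimated at 50000 nM, with a likely range from 10000 nM to 200000 nM.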

Compound 3, half-maximal inhibitory concentration: 860 nM
Compound 3: the middle estimate sits 58-fold (1.76 log units) above what was measured, outside the stated range (below it).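

In this assay, (4-nitrophenyl)sulfonyl on the nitrogen of the seven-membered non-aromatic ring gives a 57-fold lower number from compound 2 to compound 3 (1.75 log units; beyond the scatter), so this position accepts a large group and the number falls sharply. Phenylsulfanyl in place of hydroxy on an aromatic carbon gives an at least 110-fold lower number from compound 1 to compound 3 (2.06 log units; beyond the scatter), so the sulfonyl group does not bring this result without phenylsulfanyl present. Compound 1 sits at a limit, so this step has no exact size: the limit of > 100000 nM in this assay, at which 1 of the 3 values shown sits.

The compounds shown leave open whether an acetyl group or a plain benzenesulfonyl group on this nitrogen would give a similar step. They also leave open whether the nitro group takes part in it.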